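From (3,4-dimethylphenyl)amino to piperidin-1-yl on the shared core

This account rests on a few compounds, and the source may have more. Where it says the series, first, only, none or still open, it means among the compounds named here.

Compound 1 `Cc1ccc(NC2=CC(=O)c3nc4n(c3C2=O)[C@H]2OC[C@@H](O)[C@H]2OC4)cc1C`: 860 nM
Compound 2 `O=C1C(NC2CCCCC2)=CC(=O)c2c1nc1n2[C@H]2OC[C@@H](O)[C@H]2OC1`: > 8000 nM, a limit
Compound 3 `O=C1C(N2CCCC2)=CC(=O)c2c1nc1n2[C@H]2OC[C@@H](O)[C@H]2OC1`: > 16000 nM, a limit

Within the data shown here, in a functional assay on MGC-803 cells (Homo sapiens) for inhibition, read by sulforhodamine B assay (a lower number here means a stronger inhibitor, a higher number a weaker inhibitor), compound 1 gives 860 nM, the only true number among the three values shown. For compound 2 the result is a limit, > 8000 nM. For compound 3 the result is likewise a limit, > 16000 nM. The step that the two limits leave unreadable from compound 2 to compound 3 cannot be read, since both ends are limits. Compound 4 `O=C1C=C(N2CCCCC2)C(=O)c2c1nc1n2[C@H]2OC[C@@H](O)[C@H]2OC1` differs from compound 1 in one place: piperidin-1-yl in place of (3,4-dimethylphenyl)amino on a double-bonded ring carbon. Among the measured compounds shown here, no measured step removes the (3,4-dimethylphenyl)amino group directly; the two compounds carrying non-aromatic amines, compound 2 and compound 3, sit at the limit of > 8000 nM in this assay, at which 1 of the 3 values shown sits, and (the limit of > 16000 nM in this assay, at which 1 of the 3 values shown sits). A loss of potency is therefore expected, quite possibly ending in a limit again. Compound 4 is estimated at 10000 nM (3000 nM to 32000 nM), the expected step being a 12-fold higher number from compound 1 to compound 4 (1.07 log units; beyond the scatter).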

Compound 4, half-maximal inhibitory concentration: > 8000 nM
Compound 4 gave a limit, no number; the forecaster's own chance of this, stated with the estimate: 55%; the middle value lies beyond the limit too.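

In this assay, among these compounds, the change to piperidin-1-yl gives an at least 9.3-fold higher number from compound 1 to compound 4 (0.96 log units; beyond the scatter), the only readable step at this double-bonded ring carbon. The result for compound 4 is a limit, so the full size of the step stays unknown: the limit of > 8000 nM in this assay, at which 2 of the 4 values shown sit. Among the compounds shown, only compound 1, which carries the aromatic ring, gives a true number, while compound 2, compound 3 and compound 4, with non-aromatic amines, all end at limits.

The compounds shown leave open whether the aromatic ring or the amine hydrogen matters more. A plain phenylamino group, or an N-methyl-N-phenylamino group, would help separate the two.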